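Aryl Amine in Place of Cyclopentyl Amine on the Core

The source may report more compounds than this note shows. Statements on the series, on what has been measured and on what is new or still open speak of the compounds shown alone.

Compound 1 `O=C1C(Nc2ccccc2F)=CC(=O)c2c1nc1n2[C@H]2OC[C@@H](O)[C@H]2OC1` gives 2000 nM in a functional assay on MGC-803 cells (Homo sapiens) for inhibition, read by sulforhodamine B assay; on this read-out lower numbers stand for stronger inhibition and higher numbers for weaker inhibition.
Compound 2 `O=C1C(N2CCCC2)=CC(=O)c2c1nc1n2[C@H]2OC[C@@H](O)[C@H]2OC1` reaches only the limit > 16000 nM in this assay.
Compound 3 `O=C1C=C(NC2CCCC2)C(=O)c2c1nc1n2[C@H]2OC[C@@H](O)[C@H]2OC1` reaches only the limit > 8000 nM in this assay.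

Among the three measured compounds, compound 3 stands at a limit rather than a number: the limit of > 8000 nM in this assay, at which 1 of the 3 values shown sits. Compound 4 `O=C1C=C(Nc2ccc(I)cc2)C(=O)c2c1nc1n2[C@H]2OC[C@@H](O)[C@H]2OC1` is the next compound to be measured. Its difference from compound 3 is 4-iodophenyl in place of cyclopentyl on an amine nitrogen.

Among the compounds with values here, one measured step bears on this change. Compound 1 carries an aromatic amine, a (2-fluorophenyl)amino group, on a double-bonded ring carbon, and in this assay there is an at least 8.0-fold higher number from compound 1 to compound 2 (0.90 log units; beyond the scatter), where the arylamine gives way to a non-aromatic pyrrolidin-1-yl ring. As far as these compounds go, compound 2 sits at a limit, (the limit of > 16000 nM in this assay, at which 1 of the 3 values shown sits), so the true size of that step is unknown, but it is at least modest. The step to compound 4 runs the other way: a non-aromatic cyclopentyl gives way to an aromatic 4-iodophenyl on the amine nitrogen. A lower number is therefore expected, and compound 4 is estimated at 3000 nM, with a range from 800 nM to 12000 nM, meaning an expected at least 2.6-fold lower number from compound 3 to compound 4 (0.42 log units; beyond the scatter).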

Compound 4, half-maximal inhibitory concentration: 1400 nM
The estimate for compound 4 lay 2.1-fold (0.33 log units) above the measured number, and the stated range covers the measured number.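

In this assay, changing cyclopentyl to 4-iodophenyl on the amine nitrogen, with the rest of the molecule untouched, gives an at least 5.7-fold lower number from compound 3 to compound 4 (0.75 log units; beyond the scatter). The earlier step replaced a whole (2-fluorophenyl)amino group with pyrrolidin-1-yl, so the ring and the way it was attached to the core changed together; here the amine nitrogen stays in place and only the group on it differs, which shows that the ring swap alone is enough to move the number beyond the scatter. The real size of this step remains unknown because compound 3 sits at a limit and not at a number: the limit of > 8000 nM in this assay, at which 1 of the 4 values shown sits.

The step also changes two things at once, a non-aromatic ring for an aromatic one and the arrival of an iodine, so the compounds shown cannot assign the lower number to either. A plain phenyl on the same nitrogen would separate the two, and a chlorine or a methoxy group in place of the iodine would show whether the iodine itself matters.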